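The source may report more compounds than this note shows. Statements on the series, on what has been measured and on what is new or still open speak of the compounds shown alone.

Measured compounds in a functional assay on the whole organism (strain Wistar) for inhibition, with Rattus norvegicus as the target, read by paw edema, with stated times of 30 min and 5 h, at a dose of 100 mg/kg by the oral route; on this read-out higher numbers stand for more inhibition at the one dose given (going by the name of the read-out) and lower numbers for less inhibition:
Compound 1 `CCCCCOc1cc(C(C)=O)ccc1NS(C)(=O)=O` gives 59.6%.
Compound 2 `CCCCCCOc1cc(C(C)=O)ccc1N` gives 14.1%.
Compound 3 `CCCCCCOc1cc(C(C)=O)ccc1NS(C)(=O)=O` gives 76.8%.

Compound 2 stands lowest of the three in this assay, with compound 1 nearest and compound 3 furthest. The unmeasured compound 4 `CCCCCOc1cc(C(C)=O)ccc1N` differs from compound 2 by hydrogen in place of methyl on a saturated chain carbon, five bonds along the chain from an oxygen on an aromatic ring. Among the measured compounds shown here, only one measured step touches that chain carbon: a number 17.2 percentage points higher from compound 1 to compound 3 (beyond the scatter), on the sulfonamide pair. The step to compound 4 runs the other way, so a modest fall is expected, though compound 2 already sits low and leaves little room downward. The other step, a number 62.7 percentage points higher from compound 2 to compound 3 (beyond the scatter), concerns the nitrogen and does not bear on this change. Compound 4 is therefore expected at 5%, within -10% to 22%, an estimated step of a number 9.1 percentage points lower from compound 2 to compound 4 (within the scatter).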

Compound 4, a percentage reported as inhibition, in the whole organism at one dose (the size of the read-out at that dose, not a potency): 9.88%
For compound 4 the middle estimate is 4.9 percentage points below the measured one; the range from low to high includes it.
By their numbers in this assay, from the lowest: compounds 4 and 2 (each within the scatter of the next); then compound 1; then compound 3.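

In this assay, where the nitrogen carries no methylsulfonyl, hydrogen in place of methyl on this chain carbon gives a number 4.2 percentage points lower from compound 2 to compound 4 (within the scatter), so the change cannot be told from scatter on this core. Even so, the two cores cannot be said to respond differently to the change: the same change on two cores in this assay, a number 17.2 percentage points higher (beyond the scatter) from compound 1 to compound 3 and a number 4.2 percentage points higher (within the scatter) from compound 4 to compound 2, 13 percentage points apart, within the scatter of two such steps Hydrogen in place of methylsulfonyl on the nitrogen also gives a number 49.7 percentage points lower from compound 1 to compound 4 (beyond the scatter), which shows that the large effect of this group holds on the shorter chain as well: the same change on two cores in this assay, a number 62.7 percentage points higher (beyond the scatter) from compound 2 to compound 3 and a number 49.7 percentage points higher (beyond the scatter) from compound 4 to compound 1, 13 percentage points apart, within the scatter of two such steps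

Going by these compounds, whether a longer chain on the oxygen would change the read-out remains open. So does the effect of an acetyl group on the nitrogen in place of methylsulfonyl.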